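A few compounds are considered here, and "the series" means these few. Any claim that something is new, unique, unknown or untested is made for them only; others in the source may bear on it.

Measured compounds:
- compound 1 `O=S(=O)(NCCCCNCc1ccc(Br)cc1)c1cc(C(F)(F)F)cc(C(F)(F)F)c1`: 2200 nM
- compound 2 `O=S(=O)(NCCCNCc1ccc(Cl)c(Cl)c1)c1cc(C(F)(F)F)cc(C(F)(F)F)c1`: 5600 nM
- compound 3 `O=S(=O)(NCCCNCc1cccc(Cl)c1)c1cc(C(F)(F)F)cc(C(F)(F)F)c1`: 12000 nM

In a functional assay on PANC-1 cells (Homo sapiens) for inhibition, read by MTT assay, with a stated time of 72 h (on this read-out higher numbers stand for weaker inhibition of growth and lower numbers for stronger inhibition of growth), compound 3 gives the highest of the three numbers shown. The nearest is compound 2, a 2.1-fold higher number from compound 2 to compound 3 (0.33 log units; beyond the scatter); the furthest is compound 1, a 5.5-fold higher number from compound 1 to compound 3 (0.74 log units; beyond the scatter). The step of a 2.5-fold higher number from compound 1 to compound 2 (0.41 log units; beyond the scatter) lies between these two.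

Compound 4 `COc1ccccc1CNCCCNS(=O)(=O)c1cc(C(F)(F)F)cc(C(F)(F)F)c1` differs from compound 3 in one place: 2-methoxyphenyl in place of 3-chlorophenyl on a saturated chain carbon bound to an amine nitrogen. The measured steps bear on this only loosely: each of them changes the benzyl part carried by the amine nitrogen, and each such change was modest in this assay. Within the data shown here, no measured pair touches a methoxy group, so the direction of the step cannot be read from the three numbers. The benzyl changes seen so far moved the number by modest amounts, so a step of similar size or none beyond the scatter is expected, with no strong basis for either direction.

For compound 4 the estimated value in this assay is 14000 nM, within 5000 nM to 40000 nM. This corresponds to an expected step of a 1.2-fold higher number from compound 3 to compound 4 (0.07 log units; within the scatter).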

Compound 4, concentration for 50% growth inhibition: 12000 nM
Compound 4: the middle estimate sits 1.2-fold (0.07 log units) above what was measured, within the range that was stated.
By their numbers in this assay, from the lowest: compound 1; then compound 2; then compounds 3 and 4 (each within the scatter of the next).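

In this assay, the step to 2-methoxyphenyl from 3-chlorophenyl on the saturated chain carbon bound to the amine nitrogen gives no change at the digits printed from compound 3 to compound 4 (within the scatter), so these two groups cannot be told apart here, although one carries a chlorine and the other an oxygen with a hydrogen-bond acceptor. The 3,4-dichlorophenyl group still has the lower number, with a 2.1-fold higher number from compound 2 to compound 4 (0.33 log units; beyond the scatter), so the new group does not reach the level of that group. The ((4-bromobenzyl)amino)methyl group leaves the widest gap, with a 5.5-fold higher number from compound 1 to compound 4 (0.74 log units; beyond the scatter). No supporting evidence accounts for these numbers.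

The series shown does not separate the effect of the bromine from that of the extra chain carbon in compound 1. It also leaves open how a nitrile or a hydroxyl on the phenyl ring would read.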